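Cytotoxicity notes on the tert-butoxy acid series

This account rests on a few compounds, and the source may have more. Where it says the series, first, only, none or still open, it means among the compounds named here.

Measured compounds:
compound 1 `CC(=O)N1CCc2nc(C)c(C(OC(C)(C)C)C(=O)O)c(-c3ccc(C)cc3)c2C1` gives > 40000 nM
compound 2 `CCCCCN1CCc2nc(C)c(C(OC(C)(C)C)C(=O)O)c(-c3ccc(C)cc3)c2C1` gives > 40000 nM
compound 3 `COC(=O)N1CCc2nc(C)c(C(OC(C)(C)C)C(=O)O)c(-c3ccc(C)cc3)c2C1` gives > 40000 nM

In an ADME assay on MT2 cells (Homo sapiens) for cytotoxicity, read by XTT assay, with a stated time of 4 days (a higher number here means that more compound is tolerated, a lower number that less compound is tolerated), compound 1 gives > 40000 nM, which is a limit of the assay and not a number. Compound 2 gives > 40000 nM, again a limit. Compound 3 gives > 40000 nM, also a limit. So compound 2 stands exactly where the other two stand, at the limit of > 40000 nM in this assay, at which 3 of the 3 values shown sit. The step that the two limits leave unreadable from compound 1 to compound 2 is therefore not readable, nor are a step that the two limits leave unreadable from compound 1 to compound 3 and a step that the two limits leave unreadable from compound 2 to compound 3: none of the three changes on the amine nitrogen in the ring moved a compound off the limit.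

Compound 4 `Cc1ccc(-c2c3c(nc(C)c2C(OC(C)(C)C)C(=O)O)CCN(Cc2ccccc2-c2ccccc2)C3)cc1` is not yet measured. It differs from compound 2 by 2-phenylphenyl in place of butyl on a saturated chain carbon bound to an amine nitrogen in a ring. This is a larger change than any of the three measured steps, and none of those steps gives a readable size, so the measured steps offer no direction to carry over. The only anchor is that every measured compound sits at the limit.

Compound 4 is expected to give 25000 nM in this assay, within 6000 nM to 40000 nM. The expected step of an at least 1.6-fold lower number from compound 2 to compound 4 (0.20 log units; that floor lies within the scatter) is an estimate that leans toward a measurable value below the limit, but with much uncertainty.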

Compound 4, half-maximal cytotoxic concentration: > 40000 nM
Compound 4: only a limit was reported; the forecaster's own chance of this, stated with the estimate: 45%; middle value at least 1.6-fold (0.20 log units) from the limit.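

No new step can be read between compound 2 and compound 4: compound 4 gives > 40000 nM, a limit of the assay and not a number. The series stands as before: the limit of > 40000 nM in this assay, at which 4 of the 4 values shown sit.

The compounds shown leave open at what concentration any of them becomes cytotoxic in this assay, and whether the group on the amine nitrogen in the ring changes that concentration.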